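Swapping the amide group of compound 3

The source may hold more compounds than are shown below. What is called first, only, known or untested is meant among the compounds shown, and "the series" means these compounds.

In an ADME assay on L02 cells (Homo sapiens) for antiproliferative activity, read by MTT assay, with a stated time of 48 h (a higher number here means a weaker inhibitor, a lower number a stronger inhibitor), compound 1 `CCn1c(C(=O)NCCN(C)C)ccc1C(CC)(CC)c1ccc(OCCC(O)(CC)CC)c(C)c1` gives 990 nM. Compound 2 `C#CC(C)OC(=O)c1ccc(C(CC)(CC)c2ccc(OCCC(O)(CC)CC)c(C)c2)n1CC` gives > 50000 nM, which is a limit of the assay and not a number. Compound 3 `CCn1c(C(=O)NC(CC(=O)O)C(=O)OC)ccc1C(CC)(CC)c1ccc(OCCC(O)(CC)CC)c(C)c1` gives 7590 nM, the higher of the two actual numbers. Compound 4 `CCn1c(C(=O)NC(C)C(=O)O)ccc1C(CC)(CC)c1ccc(OCCC(O)(CC)CC)c(C)c1` alters one group: a group of 5 heavy atoms (3 carbon, 2 oxygen; no ring) in place of a group of 9 heavy atoms (5 carbon, 4 oxygen; no ring), on an amide-type nitrogen. The closest measured change, also made on the amide-type nitrogen, is a 7.7-fold higher number from compound 1 to compound 3 (0.88 log units; beyond the scatter). Changes on the carbonyl carbon went further, with an at least 50-fold higher number from compound 1 to compound 2 (1.70 log units; beyond the scatter) and an at least 6.5-fold lower number from compound 2 to compound 3 (0.81 log units; beyond the scatter). Since the carbonyl and its amide-type nitrogen stay in place here, only a small shift is expected. The expected step is a 1.2-fold higher number from compound 3 to compound 4 (0.07 log units; within the scatter), which would not go beyond the scatter. For compound 4 the estimated value is 9000 nM, with a range of 2500 nM to 35000 nM.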

Compound 4, half-maximal inhibitory concentration: 4040 nM
The estimate for compound 4 lay 2.2-fold (0.35 log units) above the measured number, within the range that was stated.
By their numbers in this assay, from the lowest: compound 1; then compounds 4 and 3 (each within the scatter of the next). At a limit, above all of these: compound 2.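

On the amide-type nitrogen, 1-carboxyethyl and the larger group it replaces cannot be told apart, with a 1.9-fold lower number from compound 3 to compound 4 (0.27 log units; within the scatter). The 2-(dimethylamino)ethyl group still reads differently, with a 4.1-fold higher number from compound 1 to compound 4 (0.61 log units; beyond the scatter), and an amide carrying 1-carboxyethyl separates clearly from the (1-methylprop-2-yn-1-yl)oxy group on the carbonyl carbon, with an at least 12-fold lower number from compound 2 to compound 4 (1.09 log units; beyond the scatter). Compound 2 stands at a limit of the assay, not a number: the limit of > 50000 nM in this assay, at which 1 of the 4 values shown sits.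

The compounds shown leave open whether the gap to compound 1 tracks its dimethylamino end or the carboxylic acid. A plain ethyl group on that nitrogen, carrying neither, could separate the two.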